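The compounds below may be only part of what the source reports. "The series", "measured", "known", "first", "only" and "open" are said of these compounds alone.

Measured so far in a functional assay on HeLa cells (Homo sapiens) for antiproliferative activity, read by CCK-8 assay, with a stated time of 48 h; on this read-out higher numbers stand for weaker inhibition and lower numbers for stronger inhibition:
Compound 1 `COc1ccc(/C=C\c2cc(OC)c(OC)c(OC)c2)cc1OCc1ccc(CN2CCCCC2C(=O)O)cc1`: 14200 nM
Compound 2 `COc1ccc(/C=C\c2cc(OC)c(OC)c(OC)c2)cc1OCc1ccc(CN2CC[C@@H](O)C2)cc1`: > 10000 nM

The entry for compound 2 is a limit and not a number: > 10000 nM.

Compound 3 `COc1ccc(/C=C\c2cc(OC)c(OC)c(OC)c2)cc1OCc1ccc(CN[C@H](C(=O)O)[C@@H](C)O)cc1` carries (1-carboxy-2-hydroxypropyl)amino in place of 3-hydroxypyrrolidin-1-yl on a saturated chain carbon bound to an aromatic carbon. Among the compounds with values here, the only measured step at this place is a step that the limit leaves unreadable from compound 1 to compound 2, so it offers no size to carry over. The group that compound 1 holds there, 2-carboxypiperidin-1-yl, also bears a carboxy group, and compound 1 gives 14200 nM. On that value, no step beyond the usual scatter is expected in this assay, and another limit may well be reported. The estimated change is a step that the limit leaves unreadable from compound 2 to compound 3. Compound 3 is expected at 15000 nM, within an estimated range of 6000 nM to 40000 nM.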

Compound 3, half-maximal inhibitory concentration: > 10000 nM
Compound 3: no number, only a limit (the forecaster's own chance of this, stated with the estimate: 50%); the middle value is on the limit's open side.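

In this assay compound 3 gives > 10000 nM, which is a limit and not a number. No new step can be read among compound 1, compound 2 and compound 3: the limit of > 10000 nM in this assay, at which 2 of the 3 values shown sit.

The compounds shown leave open whether, and by how much, the group at this place changes the inhibition in this assay.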